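This account rests on a few compounds, and the source may have more. Where it says the series, first, only, none or still open, it means among the compounds named here.

Compound 1 `O=C(Nc1ccc(F)c(Br)c1)C1CCN(C/C=C/c2ccccc2)CC1`: 11700 nM
Compound 2 `O=C(Nc1nccs1)C1CCN(C/C=C/c2ccccc2)CC1`: 34900 nM

Both values come from a functional assay on A549 cells (Homo sapiens) for inhibition, read by MTT assay, with a stated time of 72 h; a lower number here means a stronger inhibitor, a higher number a weaker inhibitor. Compound 2 holds the higher of the two numbers, which makes it the weaker inhibitor of this pair. The next compound, compound 3 `O=C(NCc1ccccc1)C1CCN(C/C=C/c2ccccc2)CC1`, has not yet been measured. It keeps the shared core of compound 2 and changes one group: benzyl in place of 1,3-thiazol-2-yl on an amide-type nitrogen, (benzyl in place of 1,3-thiazol-2-yl on an amide-type nitrogen).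

Going by the values given here, only one measured step bears on this change. It is a 3.0-fold higher number from compound 1 to compound 2 (0.47 log units; beyond the scatter), a modest step at the same place that also involves 1,3-thiazol-2-yl. Read backwards, it shows that compound 1, which carries a six-membered aromatic ring of carbon only, sits lower at 11700 nM. Benzyl also brings such a ring, but without the bromo and fluoro groups, and no benzyl compound has a measured value yet. A partial move towards compound 1 therefore seems the fair expectation. The expected change is small and towards a lower number: a 1.7-fold lower number from compound 2 to compound 3 (0.24 log units; within the scatter). For compound 3 the estimated value is 20000 nM, with an expected range from 8000 nM to 50000 nM.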

Compound 3, half-maximal inhibitory concentration: > 100000 nM
Compound 3: a limit, no number (the forecaster's own chance of this, stated with the estimate: 10%); middle value at least 5.0-fold (0.69 log units) away from the limit.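

In this assay compound 3 gives > 100000 nM, which is a limit of the assay and not a number, and the only such reading among these compounds: the limit of > 100000 nM in this assay, at which 1 of the 3 values shown sits. Even so, the limit is enough to place compound 3 on the weak side of both earlier compounds: benzyl in place of 1,3-thiazol-2-yl gives an at least 2.8-fold higher number from compound 2 to compound 3 (0.45 log units; beyond the scatter), and benzyl in place of 3-bromo-4-fluorophenyl gives an at least 8.5-fold higher number from compound 1 to compound 3 (0.93 log units; beyond the scatter). Going by these compounds alone, the earlier pair showed only that two groups on the amide-type nitrogen differ, whereas this result shows that having a six-membered aromatic ring of carbon only in the group is not enough to keep a compound close to compound 1.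

Benzyl differs from 3-bromo-4-fluorophenyl both in the bromo and fluoro groups and in the extra carbon, so these compounds cannot say which of the two accounts for the step. A plain phenyl on the nitrogen would separate the two, while a 3-bromo-4-fluorobenzyl or a longer chain such as 2-phenylethyl would test the same question from the other side.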